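Ester to acid in the benzylpiperidine ether series

This account rests on a few compounds, and the source may have more. Where it says the series, first, only, none or still open, it means among the compounds named here.

Measured so far in an assay on isolated protein for inhibition of Amine oxidase [flavin-containing] A (Homo sapiens), read by fluorescence, with stated times of 30 min and 1 h; on this read-out higher numbers stand for weaker inhibition and lower numbers for stronger inhibition:
- compound 1, `COc1ccc2c(c1)cc(C(=O)NCc1ccccc1)n2C`: > 100000 nM, a limit of the assay
- compound 2, `COc1ccc2c(c1)cc(CNCc1ccccc1)n2C`: > 100000 nM; 100000 nM (2 entries), several entries (the several entries of compound 2 in this assay, > 100000 nM; 100000 nM (2 entries))
- compound 3, `CCOC(=O)c1cc2cc(OCCCC3CCN(Cc4ccccc4)CC3)ccc2n1C`: 1530 nM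

Going by the values given here, compound 3 holds the only single number in this assay; one other value sits at the assay limit (the limit of > 100000 nM in this assay, at which 1 of the 3 values shown sits) and the remaining compound carries several entries with no single number. Among the compounds with values here, no step between two measured compounds is available.

Compound 4, `Cn1c(C(=O)O)cc2cc(OCCCC3CCN(Cc4ccccc4)CC3)ccc21`, differs from compound 3 by hydrogen in place of ethyl on an oxygen next to a carbonyl group. Within the data shown here, with no comparable step among the measured compounds, the expectation rests only on the change itself: a weakening beyond the scatter is expected, a 9.8-fold higher number from compound 3 to compound 4 (0.99 log units; beyond the scatter). Compound 4 is therefore estimated at 15000 nM, within 3000 nM to 80000 nM.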

Compound 4, half-maximal inhibitory concentration: > 100000 nM
Compound 4: only a limit was reported; the forecaster's own chance of this, stated with the estimate: 25%; middle value at least 6.6-fold (0.82 log units) away from the limit.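

In this assay compound 4 gives > 100000 nM, which is a limit of the assay, and it joins the other value at that limit: the limit of > 100000 nM in this assay, at which 2 of the 4 values shown sit.

Going by these compounds alone, this is the first readable step: replacing ethoxycarbonyl with carboxy gives an at least 65-fold higher number from compound 3 to compound 4 (1.81 log units; beyond the scatter). The measurable inhibition of compound 3 is therefore lost with this single change, and the step is bounded on one side only.

The compounds shown leave open whether the loss follows the removal of ethyl or the presence of the carboxylic acid. A methyl ester or a primary amide at this place would separate the two.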